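A few compounds are considered here, and "the series" means these few. Any claim that something is new, unique, unknown or untested is made for them only; others in the source may bear on it.

Measured in a functional assay on HeLa cells (Homo sapiens) for cytotoxicity, read by sulforhodamine B assay, with a stated time of 48 h; a lower number here means a stronger inhibitor, a higher number a weaker inhibitor:
- compound 1 `C=CCOc1cc(Br)ccc1C(=O)c1cccnc1`: > 100000 nM
- compound 2 `O=C(c1cccnc1)c1cc(Cl)cc(Cl)c1O`: > 100000 nM
- compound 3 `O=C(c1cccnc1)c1cccc(Cl)c1O`: 21000 nM

Compound 1 stands at the limit of > 100000 nM in this assay, at which 2 of the 3 values shown sit; its reading is a limit, not a number. The reading of compound 2 is also a limit.

Compound 4 `C=CCOc1ccccc1C(=O)c1cccnc1` differs from compound 1 by hydrogen in place of bromo on an aromatic carbon.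

Among the measured compounds shown here, the only measured step of a similar kind is hydrogen in place of chloro on an aromatic carbon, an at least 4.7-fold lower number from compound 2 to compound 3 (0.67 log units; beyond the scatter). It involves a different halogen on a different substitution pattern, so it is only a rough guide. On that step, a move to a lower number is expected in this assay, with an at least 2.5-fold lower number from compound 1 to compound 4 (0.39 log units; beyond the scatter) as the estimated step.

The estimate for compound 4 is 40000 nM, with an expected range of 15000 nM to 100000 nM.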

Compound 4, half-maximal inhibitory concentration: > 100000 nM
Compound 4 gave a limit, no number; the forecaster's own chance of this, stated with the estimate: 35%; middle value at least 2.5-fold (0.39 log units) away from the limit.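

In this assay compound 1 and compound 4 both read as limits, not numbers, so no step between them can be read: the limit of > 100000 nM in this assay, at which 3 of the 4 values shown sit.

Going by these compounds, whether hydrogen in place of bromo on this allyloxy series changes the reading at all remains open.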